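The source may hold more compounds than are shown below. What is called first, only, known or untested is meant among the compounds shown, and "the series" means these compounds.

Measured compounds:
- compound 1, `Cc1cc(Cl)cc(-c2ccnc3cc(CN4C(=O)C5C(C4=O)C5(C)C)sc23)c1C[C@@H]1CNCCO1`: 450 nM
- compound 2, `Cc1cc(Cl)cc(-c2ccnc3cc(CN4C(=O)C5CC5C4=O)sc23)c1C[C@@H]1CNC[C@@H](C)O1`: "not determined" (no result reported)

In a functional assay on NCI-H526 cells (Homo sapiens) for cytotoxicity, read by CellTiter-Glo, with a stated time of 5 days (a higher number here means that more compound is tolerated, a lower number that less compound is tolerated), compound 1 gives 450 nM. Compound 2, `Cc1cc(Cl)cc(-c2ccnc3cc(CN4C(=O)C5CC5C4=O)sc23)c1C[C@@H]1CNC[C@@H](C)O1`, has no single number in this assay, so nothing can be said of where it stands on the scale, and the only anchor in the series is compound 1.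

Compound 3, `Cc1cc(Cl)cc(-c2ccnc3cc(CN4C(=O)C5CC5C4=O)sc23)c1C[C@@H]1CNCCO1`, is the next compound and is to be measured in this assay. It differs from compound 2 in one place: hydrogen in place of methyl on a saturated ring carbon. A change of this size, a single methyl removed from a saturated ring carbon, is expected to give a step in this assay that does not go beyond the usual scatter, in no particular direction, though with no number for compound 2 the step itself cannot be computed.

Going by the values given here, for compound 3 the half-maximal cytotoxic concentration in this assay is expected near 450 nM, within a range from 150 nM to 1500 nM, on the strength of the single value held by compound 1, 450 nM.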

Compound 3, half-maximal cytotoxic concentration: 3600 nM
Beside the measured number, compound 3's estimate is 8.0-fold (0.90 log units) below it; measured number outside the range, above it.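

In this assay, the exchange of the larger group for the smaller one on the saturated chain carbon bound to an aromatic carbon gives an 8.0-fold higher number from compound 1 to compound 3 (0.90 log units; beyond the scatter) with the morpholin-2-yl part unchanged. Going by these compounds alone, both groups carry a three-membered ring of carbon only and a five-membered non-aromatic ring with one hetero atom, so this is the first sign that the number responds to a change at this position, and more compound is tolerated with the smaller group. Nothing on hand bears on the origin of this step.

On these data alone, the step between compound 2 and compound 3 cannot be read, so the effect of going from 6-methylmorpholin-2-yl to morpholin-2-yl stays unknown. Also open, as far as these compounds go, is how the number would respond to an ethyl group or a fluorine on the three-membered ring.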